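From 2-methylphenyl to 4-hydroxyphenyl: an expected step

The source may hold more compounds than are shown below. What is called first, only, known or untested is meant among the compounds shown, and "the series" means these compounds.

In a functional assay on B16-F10 cells (Mus musculus) for inhibition, with a stated time of 4 days (a higher number here means a weaker inhibitor, a lower number a stronger inhibitor), compound 3 `COc1cc(O)c(C(=O)/C=C/c2ccccc2C)c(OC)c1` gives 3000 nM. This is level with compound 2 `COc1cc(O)c(C(=O)/C=C/c2ccccc2O)c(OC)c1` at 2300 nM and far lower than compound 1 `COc1cc(O)c(C(=O)/C=C/c2ccc(O)c(O)c2)c(OC)c1` at 31600 nM. The unmeasured compound 4 `COc1cc(O)c(C(=O)/C=C/c2ccc(O)cc2)c(OC)c1` differs from compound 3 in one place: 4-hydroxyphenyl in place of 2-methylphenyl on a double-bonded chain carbon bound to a double-bonded chain carbon. Going by the values given here, the only measured single-place step, a 1.3-fold higher number from compound 2 to compound 3 (0.12 log units; within the scatter), lies within the scatter, and it does not cover the 4-hydroxyphenyl group. Compound 1 at 31600 nM shows that a compound in this small set can reach a much higher number, so a modest rise seems more likely than a fall. The expected change is a 2.3-fold higher number from compound 3 to compound 4 (0.37 log units; beyond the scatter). The estimate for compound 4 is 7000 nM, with an expected range of 2000 nM to 25000 nM.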

Compound 4, half-maximal inhibitory concentration: 6900 nM
Compound 4: the middle estimate sits 1.0-fold (0.01 log units) above what was measured; the range from low to high includes it.
By their numbers in this assay, from the lowest: compounds 2 and 3 (each within the scatter of the next); then compound 4; then compound 1.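

In this assay 2-methylphenyl giving way to 4-hydroxyphenyl produces a 2.3-fold higher number from compound 3 to compound 4 (0.36 log units; beyond the scatter) and so shows that the group at this place can shift the number beyond the scatter. Where the hydroxy sits on the ring also counts: 4-hydroxyphenyl in place of 2-hydroxyphenyl gives a 3.0-fold higher number from compound 2 to compound 4 (0.48 log units; beyond the scatter) in this small set. Hydrogen in place of one hydroxy on an aromatic carbon gives a 4.6-fold lower number from compound 1 to compound 4 (0.66 log units; beyond the scatter) and thus makes compound 1, with its extra hydroxy, the weaker inhibitor of that pair. On these data alone, whether an amine or a carboxylic acid on this ring would raise or lower the number stays open. Nothing available explains any of these steps.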